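The source may report more compounds than this note shows. Statements on the series, on what has been measured and on what is new or still open speak of the compounds shown alone.

Working notes on the hydrazide series. Compound 1 `O=C(NNC(=O)c1cccc(NS(=O)(=O)c2cnc(O)nc2O)c1)c1cccc(Cl)c1` and compound 3 `O=C(NNC(=O)c1ccccc1NS(=O)(=O)c1cnc(O)nc1O)c1cccc(Cl)c1` are built from the same atoms joined differently; the difference between the two cores is not broken down here. In a functional assay on MDA-MB-231 cells (Homo sapiens) for antiproliferative activity, read by MTT assay, with a stated time of 24 h (a lower number here means a stronger inhibitor, a higher number a weaker inhibitor), compound 1 gives 3180 nM. In this assay compound 3 gives 4420 nM, which sits within the usual scatter of compound 1, so no order between the two is claimed.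

Compound 2 `O=C(NNC(=O)c1ccccc1F)c1cccc(NS(=O)(=O)c2cnc(O)nc2O)c1` arises from compound 1 by 2-fluorophenyl in place of 3-chlorophenyl on a carbonyl carbon. In this assay compound 2 does not return a number but only a limit, (the limit of > 20000 nM in this assay, at which 1 of the 3 values shown sits), recorded as > 20000 nM. That change gives an at least 6.2-fold higher number from compound 1 to compound 2 (0.79 log units; beyond the scatter).

The same change, (2-fluorophenyl in place of 3-chlorophenyl on a carbonyl carbon), at the same place on the other core, turns compound 3 into compound 4 `O=C(NNC(=O)c1ccccc1NS(=O)(=O)c1cnc(O)nc1O)c1ccccc1F`, which is not yet measured in this assay. Resting on the step of an at least 6.2-fold higher number from compound 1 to compound 2 (0.79 log units; beyond the scatter), compound 4 is expected to show a comparable loss, a 6.1-fold higher number from compound 3 to compound 4 (0.79 log units; beyond the scatter), and most likely to fall at the assay limit as well. The estimate for compound 4 in this assay is 27000 nM, expected between 9000 nM and 80000 nM.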

Compound 4, half-maximal inhibitory concentration: > 20000 nM
Compound 4: a limit, no number (the forecaster's own chance of this, stated with the estimate: 70%); the middle value does not contradict the limit.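

Compound 4 returns only a limit of the assay in this assay, recorded as > 20000 nM and not a number. Replacing 3-chlorophenyl with 2-fluorophenyl on the carbonyl carbon gives an at least 4.5-fold higher number from compound 3 to compound 4 (0.65 log units; beyond the scatter), so the direction of the step carries over on the two cores shown: the same change on two cores in this assay, an at least 6.2-fold higher number (0.79 log units; beyond the scatter) from compound 1 to compound 2 and an at least 4.5-fold higher number (0.65 log units; beyond the scatter) from compound 3 to compound 4; the limit leaves it open whether they differ. The true size of the loss on either core remains unread, and no difference between the cores in that loss can be claimed, nor can two cores establish a rule for the series: the limit of > 20000 nM in this assay, at which 2 of the 4 values shown sit.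

The compounds shown leave open whether the change of halogen or the change of its place accounts for the step, which a 3-fluorophenyl or a 2-chlorophenyl group on the same carbonyl carbon would separate. Also open, on these data alone, is how a group carrying an amine or a carboxylic acid on that phenyl ring would read on either core.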